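Moving two fluorines around the aryl ring of compound 2

A few compounds are considered here, and "the series" means these few. Any claim that something is new, unique, unknown or untested is made for them only; others in the source may bear on it.

Compounds measured so far:
compound 1, `COc1cccc(F)c1C1CCN(c2ccn3c(CC4CC4)nnc3c2Cl)CC1`: 304%
compound 2, `COc1c(F)ccc(F)c1C1CCN(c2ccn3c(CC4CC4)nnc3c2Cl)CC1`: 282%

Among the compounds with values here, in a functional assay on CHO cells for agonist activity at metabotropic glutamate receptor 2 (Homo sapiens), read by scintillation counting and GTPgammaS binding, with a stated time of 30 min (on this read-out higher numbers stand for larger maximal responses and lower numbers for smaller maximal responses), compound 2 gives 282%, the lower of the two numbers; the only other value is that of compound 1, and the step of a number 22 percentage points lower from compound 1 to compound 2 (beyond the scatter) lies beyond the scatter. Compound 3, `COc1ccc(F)c(F)c1C1CCN(c2ccn3c(CC4CC4)nnc3c2Cl)CC1`, has not yet been measured. It differs from compound 2 only in how the same atoms are joined: 2,3-difluoro-6-methoxyphenyl in place of 3,6-difluoro-2-methoxyphenyl on a saturated ring carbon. Within the data shown here, no measured step bears directly on this rearrangement; the one step available, a number 22 percentage points lower from compound 1 to compound 2 (beyond the scatter), concerns adding a fluorine rather than moving one, and was modest. Among the measured compounds shown here, with both measured compounds giving large responses and no step to show how a change of this sort acts, the expectation is a step of a number 7 percentage points lower from compound 2 to compound 3 (within the scatter), which is within the scatter. Compound 3 is therefore estimated to give 275%, with a likely range from 225% to 325%.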

Compound 3, largest response reached (Emax), in percent of the reference or control that the assay uses: 258%
Estimate against measurement, compound 3: 17 percentage points above, and the stated range covers the measured number.
By their numbers in this assay, from the lowest: compound 3; then compound 2; then compound 1.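

Where the fluorines sit on the aryl ring matters even when the atoms stay the same: in this assay, 2,3-difluoro-6-methoxyphenyl in place of 3,6-difluoro-2-methoxyphenyl gives a number 24 percentage points lower from compound 2 to compound 3 (beyond the scatter). Adding a fluorine to compound 1 can therefore have effects of different sizes depending on the aromatic carbon that carries it, and the arrangement in compound 3 gives the large step, a number 46 percentage points lower from compound 1 to compound 3 (beyond the scatter). No measurement shown explains why this rearrangement lowers the maximal response.

Still open, on these data alone, is whether a chlorine or a nitrile on the aryl ring would give a similar response to fluorine, or whether an ethoxy group could replace the methoxy. It is also unknown whether the same rearrangement would lower the response on a different core.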